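The source may report more compounds than this note shows. Statements on the series, on what has been measured and on what is new or still open speak of the compounds shown alone.

Three compounds have been measured in an ADME assay on HeLa cells (Homo sapiens) for cytotoxicity, read by resazurin assay, with a stated time of 2 days; a lower number here means a stronger inhibitor, a higher number a weaker inhibitor:

compound 1, `Cc1cccc(/C=C/c2ncc([N+](=O)[O-])n2C)c1`: 30900 nM
compound 2, `Cn1c([N+](=O)[O-])cnc1/C=C/c1cccc(Br)c1`: 87100 nM
compound 3, `CC(=O)OC(c1ccc(C)cc1)C(OC(C)=O)c1ncc([N+](=O)[O-])n1C`: > 100000 nM

Compound 1 and compound 2 share one core and differ by a single change, (bromo in place of methyl on an aromatic carbon). That change moved the result by a 2.8-fold higher number from compound 1 to compound 2 (0.45 log units; beyond the scatter), a modest step toward weaker inhibition.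

Compound 3 gives only a limit in this assay, not a number. The difference between the core of compound 1 and the core of compound 3 is not broken down here.

Compound 4, `CC(=O)OC(c1ccc(Br)cc1)C(OC(C)=O)c1ncc([N+](=O)[O-])n1C`, is not yet measured. It differs from compound 3 by bromo in place of methyl on an aromatic carbon. For the measured compounds named here, this is the same kind of change as the one from compound 1 to compound 2, not the same: in compound 2 the bromo sits meta to a large group, in compound 4 it sits para to a large group.

For compound 4, a step that the limit leaves unreadable from compound 3 to compound 4 is expected. This rests on the earlier step of a 2.8-fold higher number from compound 1 to compound 2 (0.45 log units; beyond the scatter), which went toward a higher number, and on compound 3 already sitting at the limit of > 100000 nM in this assay, at which 1 of the 3 values shown sits. Compound 4 is therefore estimated at 180000 nM, most likely reported again only as a limit, with a plausible range from 70000 nM to 500000 nM.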

Compound 4, half-maximal inhibitory concentration: 97700 nM
For compound 4 the middle estimate is 1.8-fold (0.27 log units) above the measured one; the measured number falls inside the stated range.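

In this assay compound 3 gives only a limit, > 100000 nM, not a number. Bromo in place of methyl, here 4-methylphenyl to 4-bromophenyl, therefore reads only as an at least 1.0-fold lower number from compound 3 to compound 4 (0.01 log units; that floor lies within the scatter), and it does not carry over as a fixed shift from the earlier core to this one: the same change on two cores in this assay, a 2.8-fold higher number (0.45 log units; beyond the scatter) from compound 1 to compound 2 and an at least 1.0-fold lower number (0.01 log units; that floor lies within the scatter) from compound 3 to compound 4, at least 2.8-fold (0.46 log units) apart, beyond the scatter of two such steps. This does not show what lies behind the difference, and the true size of the new step stays unknown; the bromo also sits in a different place on the ring in compound 2 and compound 4, so the effect of the core cannot be separated from the effect of that position.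

The compounds shown leave open what the same change would do with the bromo in the same place on both cores. They also leave open how a chloro or a methoxy group would read in that place on either core.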